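This account rests on a few compounds, and the source may have more. Where it says the series, first, only, none or still open, it means among the compounds named here.

Values in an ADME assay on Vero 76 cells (Chlorocebus sabaeus) for cytotoxicity, read by crystal violet staining, with a stated time of 96 h (a higher number here means that more compound is tolerated, a lower number that less compound is tolerated), follow
Compound 1 `FC(F)(F)c1cccc(NC(=S)Nc2ccc(I)cc2)c1` gives 9500 nM
Compound 2 `O=[N+]([O-])c1ccc(NC(=S)Nc2cccc(C(F)(F)F)c2)cc1` gives 10000 nM
Compound 3 `N#Cc1ccc(NC(=S)Nc2cccc(C(F)(F)F)c2)cc1` gives 10000 nM

Compound 1 stands level with the other two compounds, since the three values lie within the scatter of one another. The next compound, compound 4 `FC(F)(F)c1cccc(NC(=S)Nc2cccc(Br)c2)c1`, has not yet been measured. It differs from compound 1 as follows: 3-bromophenyl in place of 4-iodophenyl on an amide-type nitrogen. In words, this is 3-bromophenyl in place of 4-iodophenyl on an amide-type nitrogen.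

Two measured steps also replace the iodo group of compound 1. Compound 2 shows a 1.1-fold higher number from compound 1 to compound 2 (0.02 log units; within the scatter) and compound 3 shows a 1.1-fold higher number from compound 1 to compound 3 (0.02 log units; within the scatter) when the replacements are compared. The remaining comparison gives no change at the digits printed from compound 2 to compound 3 (within the scatter) as well. Within the data shown here, no measured compound carries a 3-bromophenyl group, so this evidence is indirect. Even so, the flat values lead to the expectation of no change beyond the scatter in either direction. The expected step is no change at the digits printed from compound 1 to compound 4 (within the scatter) in this assay on this reasoning. For compound 4 the estimated value is 9500 nM with an expected range from 4500 nM to 22000 nM when it is measured.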

Compound 4, half-maximal cytotoxic concentration: 14000 nM
For compound 4 the middle estimate is 1.5-fold (0.17 log units) below the measured one; low and high end bracket the measured number.
By their numbers in this assay, from the lowest: compounds 1, 2, 3 and 4 (each within the scatter of the next).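

The earlier steps shown here exchanged only the iodo group on an aromatic carbon, whereas this one replaces the whole 4-iodophenyl with 3-bromophenyl on an amide-type nitrogen, altering the halogen and its place on the ring together. In this assay this double alteration gives a 1.5-fold higher number from compound 1 to compound 4 (0.17 log units; within the scatter), so the flat picture seen with nitro and cyano extends to this change of aryl group in these four compounds. Nothing measured here accounts for this result.

The compounds shown do not separate the halogen from its place on the ring, as 4-bromophenyl is not among them. They also leave open whether an amine or a carboxylic acid on this ring, or a carbonyl in place of the thiocarbonyl, would take the value beyond the scatter.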